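Cytotoxicity of a Glycoside Enone Series: Swapping the Aryl Group

The compounds below may be only part of what the source reports. "The series", "measured", "known", "first", "only" and "open" are said of these compounds alone.

Compound 1: `CC(=O)OC[C@H]1O[C@@H](CC(=O)/C=C/c2ccc(C(F)(F)F)cc2)[C@H](OC(C)=O)[C@@H](OC(C)=O)[C@@H]1OC(C)=O` — 103 nM
Compound 2: `CC(=O)OC[C@H]1O[C@@H](CC(=O)/C=C/c2ccco2)[C@H](OC(C)=O)[C@@H](OC(C)=O)[C@@H]1OC(C)=O` — "not determined" (no result reported)
Compound 3: `CC(=O)OC[C@H]1O[C@@H](CC(=O)/C=C/c2cc(Cl)cc(Cl)c2)[C@H](OC(C)=O)[C@@H](OC(C)=O)[C@@H]1OC(C)=O` — 32.9 nM

Three compounds share a peracetylated sugar core carrying an enone chain that ends in an aryl ring, and they were examined in an ADME assay on cells (Epithelial cell, Homo sapiens) for cytotoxicity, read by MTT assay, with a stated time of 24 h; on this read-out higher numbers stand for lower toxicity in this test and lower numbers for higher toxicity in this test. Compound 1 gives 103 nM, the highest of the two numbers recorded. Compound 3 gives 32.9 nM. Compound 2 gives "not determined" (no result reported), so no number is available for it. Within the data shown here, the one step between measured compounds, a 3.1-fold lower number from compound 1 to compound 3 (0.50 log units; beyond the scatter), shows that exchanging the aryl substituent pattern can move the number beyond the scatter, with the dichlorinated ring giving the lower, more toxic value.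

Compound 4, `CC(=O)OC[C@H]1O[C@@H](CC(=O)/C=C/c2ccc(C)cc2)[C@H](OC(C)=O)[C@@H](OC(C)=O)[C@@H]1OC(C)=O`, has not yet been measured. It differs from compound 1 by methyl in place of trifluoromethyl on an aromatic carbon. Among the measured compounds shown here, the only step that bears on this change is the aryl swap from compound 1 to compound 3, and it is modest in size. A methyl for a trifluoromethyl is a smaller alteration than that one, so the expected step of a 1.2-fold higher number from compound 1 to compound 4 (0.07 log units; within the scatter) is within the scatter or only slightly upward. Compound 4 is therefore estimated at 120 nM, with a range from 50 nM to 300 nM in this assay.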

Compound 4, half-maximal cytotoxic concentration: 3.18 nM
For compound 4 the middle estimate is 38-fold (1.58 log units) above the measured one, outside the stated range (below it).
By their numbers in this assay, from the lowest: compound 4; then compound 3; then compound 1.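

In this assay, replacing trifluoromethyl with methyl on this aromatic carbon, para to a large group, gives a 32-fold lower number from compound 1 to compound 4 (1.51 log units; beyond the scatter), which is larger than the earlier 3.1-fold lower number from compound 1 to compound 3 (0.50 log units; beyond the scatter), so this single place on the ring can move the number much further than the first aryl exchange suggested. The 4-methylphenyl ring also separates clearly from the 3,5-dichlorophenyl ring, with a 10-fold lower number from compound 3 to compound 4 (1.01 log units; beyond the scatter), and with both of its steps beyond the scatter, compound 4 is the most toxic of the three measured compounds in this test. Nothing available accounts for the size of these steps.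

The compounds shown leave open whether a methoxy, an ethyl, an amine or a carboxylic acid on the same aromatic carbon would give a number close to that of compound 4 or close to that of compound 1. They also leave open whether the large step from trifluoromethyl to methyl would persist with free hydroxyl groups in place of the acetyl esters on the shared core.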